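Methoxy for trifluoromethyl: an expected shift in cytotoxicity

The source may report more compounds than this note shows. Statements on the series, on what has been measured and on what is new or still open speak of the compounds shown alone.

Compound 1 `C=C1C[C@]23C[C@@]1(O)CC[C@H]2c1ccc(O)c(C)c1[C@@H]3Cn1cc(-c2ccc(C(F)(F)F)cc2)nn1` was tested in a functional assay on HL-60 cells (Homo sapiens) for cytotoxicity, read by MTT assay, with a stated time of 4 days (on this read-out lower numbers stand for stronger inhibition and higher numbers for weaker inhibition), and gave 8950 nM, the highest of the three numbers measured. Its nearest neighbour is compound 3 `C=C1C[C@]23C[C@@]1(O)CC[C@H]2c1cc(Br)c(O)c(C)c1[C@@H]3Cn1cc(-c2ccc(C(F)(F)F)cc2)nn1`, which gives 7380 nM in this assay; the step from compound 1 to compound 3 (a 1.2-fold lower number from compound 1 to compound 3 (0.08 log units; within the scatter)) introduces bromo in place of hydrogen on an aromatic carbon. Furthest away is compound 2 `C=C1C(=O)[C@]23C[C@@]1(O)CC[C@H]2c1ccc(O)c(C)c1[C@@H]3Cn1cc(-c2ccc(OC)cc2)nn1`, which gives 1150 nM in this assay, a gap from compound 1 that lies beyond the scatter.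

Compound 4 `C=C1C[C@]23C[C@@]1(O)CC[C@H]2c1ccc(O)c(C)c1[C@@H]3Cn1cc(-c2ccc(OC)cc2)nn1` has not yet been measured. It differs from compound 1 in one place: methoxy in place of trifluoromethyl on an aromatic carbon. Among the compounds with values here, no measured step isolates this change. Compound 2 also carries the methoxyphenyl group, but it differs from compound 4 elsewhere in the core as well, so its value only hints at the direction. Compound 4 is therefore expected to give a lower number than compound 1, with the step of a 2.2-fold lower number from compound 1 to compound 4 (0.35 log units; beyond the scatter) uncertain in size; its estimated value is 4000 nM, within a range from 1400 nM to 11000 nM.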

Compound 4, half-maximal inhibitory concentration: > 20000 nM
Compound 4 was reported as a limit; the forecaster's own chance of this, stated with the estimate: 3%; middle value at least 5.0-fold (0.69 log units) away from the limit.
By their numbers in this assay, from the lowest: compound 2; then compounds 3 and 1 (each within the scatter of the next). At a limit, above all of these: compound 4.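

In this assay, within the data shown here, the change from 4-(trifluoromethyl)phenyl to 4-methoxyphenyl on the core of compound 1 is the first change at this position that can be read on its own, and it moves the number upward (as an at least 2.2-fold higher number from compound 1 to compound 4 (0.34 log units; beyond the scatter)). Compound 2 carries the same 4-methoxyphenyl group and gives 1150 nM, so that group does not bring a low number with it on every core shown. The result for compound 4 is a limit and not a measured number: the limit of > 20000 nM in this assay, at which 1 of the 4 values shown sits.

As far as these compounds go, how far compound 4 truly lies from compound 1 stays open, as does whether the same change would act alike on the bromo core of compound 3. Also open is how an amine or a carboxylic acid in place of trifluoromethyl would read in this assay, since neither group appears among these compounds.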